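The source may report more compounds than this note shows. Statements on the series, on what has been measured and on what is new or still open speak of the compounds shown alone.

Measured compounds in a functional assay on HEK293 cells for antagonist activity at transient receptor potential cation channel subfamily V member 1 (Rattus norvegicus), read by calcium flux; on this read-out lower numbers stand for stronger inhibition and higher numbers for weaker inhibition:
compound 1 `FC(F)(F)c1ccc(Nc2ncnc3c2CCN(c2ncccc2C(F)(F)F)C3)cc1` gives 71 nM
compound 2 `CN(c1nc2c(Nc3ccc(C(F)(F)F)cc3)ncnc2s1)c1c(Cl)cccc1Cl` gives 540 nM
compound 3 `Cc1cccc(C)c1Nc1nc2c(Nc3ccc(C(F)(F)F)cc3)ncnc2s1` gives 6 nM

Compound 3 stands lowest of the three numbers in this assay; compound 1 is nearest and compound 2 furthest, both gaps beyond the scatter. Compound 4 `CSc1ccccc1Nc1nc2c(Nc3ccc(C(F)(F)F)cc3)ncnc2s1` is not yet measured. It differs from compound 3 in one place: 2-(methylsulfanyl)phenyl in place of 2,6-dimethylphenyl on a nitrogen on an aromatic ring. Among the measured compounds shown here, the only measured step, a 90-fold lower number from compound 2 to compound 3 (1.95 log units; beyond the scatter), altered both the aryl group and the methyl on that nitrogen at once, so it does not isolate the present exchange, and no other step does. For the measured compounds named here, with compound 3 as anchor and no direct precedent, a moderate rise in this assay is expected, the step of a 3.3-fold higher number from compound 3 to compound 4 (0.52 log units; beyond the scatter) being the estimate. Compound 4 is expected to give about 20 nM, within 5 nM to 80 nM.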

Compound 4, half-maximal inhibitory concentration: 26 nM
Beside the measured number, compound 4's estimate is 1.3-fold (0.11 log units) below it; low and high end bracket the measured number.
By their numbers in this assay, from the lowest: compound 3; then compound 4; then compound 1; then compound 2.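

In this assay, among the compounds shown here, the aryl group on this nitrogen can be exchanged at a modest cost: 2-(methylsulfanyl)phenyl in place of 2,6-dimethylphenyl gives a 4.3-fold higher number from compound 3 to compound 4 (0.64 log units; beyond the scatter), the first step that isolates this aryl group. The second secondary amine also stands well clear of the methylated amine, with a 21-fold lower number from compound 2 to compound 4 (1.32 log units; beyond the scatter). Nothing measured here explains either step.

Going by these compounds, how much of those large steps belongs to the methyl on the nitrogen and how much to the aryl group stays open. So does whether a methoxy group or a longer alkylsulfanyl chain could replace methylsulfanyl.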